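Bromophenoxy aryl ether series: chain terminus and cytotoxicity

The source may hold more compounds than are shown below. What is called first, only, known or untested is meant among the compounds shown, and "the series" means these compounds.

Measured so far:
compound 1 `OCCOc1c(Br)cc(Br)cc1Oc1ccc(Br)cc1Br` — 34.5 ug/mL
compound 2 `C=CCOc1c(Br)cc(Br)cc1Oc1ccc(Br)cc1Br` — 29 ug/mL
compound 3 `C#CCOc1c(Br)cc(Br)cc1Oc1ccc(Br)cc1Br` — 29.5 ug/mL

Within the data shown here, in a functional assay on U-937 cells (Homo sapiens) for cytotoxicity, read by MTT assay, with a stated time of 24 h (on this read-out lower numbers stand for stronger inhibition and higher numbers for weaker inhibition), compound 1 gives the highest of the three numbers, but none of the measured steps leaves the scatter: a 1.2-fold lower number from compound 1 to compound 2 (0.08 log units; within the scatter), a 1.2-fold lower number from compound 1 to compound 3 (0.07 log units; within the scatter) and a 1.0-fold higher number from compound 2 to compound 3 (0.01 log units; within the scatter). Exchanging the group on the saturated chain carbon bound to the ring oxygen has so far left the read-out unchanged.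

Compound 4 `CN1CCN(CCCCCOc2c(Br)cc(Br)cc2Oc2ccc(Br)cc2Br)CC1` differs from compound 1 at the same chain: 3-(4-methylpiperazin-1-yl)propyl in place of hydroxy on a saturated chain carbon, two bonds along the chain from an oxygen on an aromatic ring. Among the measured compounds shown here, the three measured steps all concern this position, and all were within the scatter, so the only guidance is that variation here has not moved the number. For the measured compounds named here, none of them introduces a ring or a group of comparable size, so they give no direction for this step. The expectation for compound 4 in this assay is therefore a step of a 1.2-fold lower number from compound 1 to compound 4 (0.09 log units; within the scatter), essentially none beyond the scatter. Compound 4 is estimated at 28 ug/mL, in a range of 7 ug/mL to 70 ug/mL.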

Compound 4, half-maximal inhibitory concentration: 49.1 ug/mL
Beside the measured number, compound 4's estimate is 1.8-fold (0.24 log units) below it; the range from low to high includes it.
By their numbers in this assay, from the lowest: compounds 2, 3, 1 and 4 (each within the scatter of the next).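

In this assay, among these compounds, the earlier compounds showed only that exchanging small chain ends leaves the number within the scatter; compound 4 extends this to a much larger group. Replacing hydroxy with 3-(4-methylpiperazin-1-yl)propyl adds 10 heavy atoms in place of 1 and a six-membered non-aromatic ring with 2 hetero atoms, yet gives a 1.4-fold higher number from compound 1 to compound 4 (0.15 log units; within the scatter), so this position has not yet shown a step beyond the scatter. No evidence bearing on this result is available.

Open, on these data alone, is whether a carboxylic acid or a primary amine at the chain end would move the number beyond the scatter. Also open, as far as these compounds go, is whether a morpholine in place of the methylpiperazine, or a shorter chain carrying the same ring, would give a different reading.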